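The source may hold more compounds than are shown below. What is called first, only, known or untested is meant among the compounds shown, and "the series" means these compounds.

Measured so far in a physicochemical assay for lipophilicity, measured as octanol-water partition, at pH 7.4; on this read-out lower numbers stand for lower lipophilicity and higher numbers for higher lipophilicity:
- compound 1 `CC(C)c1noc(N2CCC(Oc3cc(N4CCc5cc(C6CCCCC6=O)ccc54)ncn3)CC2)n1` gives 4.7
- compound 2 `CC(C)c1noc(N2CCC(Oc3cc(N4CCc5cc(N6CCCNS6(=O)=O)ccc54)ncn3)CC2)n1` gives 3.2

Compound 2 stands lowest of these two numbers, and the gap to compound 1 lies beyond the scatter. Compound 3 `CC(C)c1noc(N2CCC(Oc3cc(N4CCc5cc(N6CC(O)CCC6=O)ccc54)ncn3)CC2)n1` keeps the shared core, and its change is a group of 8 heavy atoms (5 carbon, 1 nitrogen, 2 oxygen; one six-membered non-aromatic ring with 1 hetero atom) in place of a group of 8 heavy atoms (3 carbon, 2 nitrogen, 2 oxygen, 1 sulfur; one six-membered non-aromatic ring with 3 hetero atoms), on an aromatic carbon at one place, on an aromatic carbon of a six-membered aromatic ring of carbon only. Within the data shown here, the one measured step that bears on this is a number 1.50 log units lower from compound 1 to compound 2 (beyond the scatter) and it is large. That step shows that an exchange at this place can move this assay a long way. However, no measured compound carries the 5-hydroxy-2-oxopiperidin-1-yl group, so its size does not carry over directly. The two exchanged groups match in the counted heavy atoms, donors and acceptors, so a small change from compound 2 at 3.2 seems the best guess. The expected change is a number 0.10 log units lower from compound 2 to compound 3 (within the scatter) and it is not expected to go beyond the scatter. The estimate for compound 3 is 3.1 with an expected range from 2.6 to 3.6 on this scale.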

Compound 3, distribution coefficient: 2.6
Compound 3: middle estimate off by 0.50 log units, on the high side, and the stated range covers the measured number.
By their numbers in this assay, from the lowest: compound 3; then compound 2; then compound 1.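

In this assay, exchanging the leaving ring on the aromatic carbon for 5-hydroxy-2-oxopiperidin-1-yl gives a number 0.60 log units lower from compound 2 to compound 3 (beyond the scatter). The two groups match in heavy atoms, hydrogen-bond donors and hydrogen-bond acceptors, so these counts alone do not settle the number at this position. Set against 2-oxocyclohexyl, the same group gives a number 2.10 log units lower from compound 1 to compound 3 (beyond the scatter), a wider step than the one first seen at this place, and nothing shown here explains either step.

Still open, on these data alone, is how much of these steps belongs to the hydroxy group, which a 2-oxopiperidin-1-yl group without it would help to separate from the rest of the ring. As far as these compounds go, it is also open where the number would fall with an amine or a carboxylic acid in place of that hydroxy group.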